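Swapping the aryl group on a saturated ring carbon

The source may hold more compounds than are shown below. What is called first, only, known or untested is meant among the compounds shown, and "the series" means these compounds.

- compound 1 `CCOC(=O)C1=C(C[Se]C(=O)c2ccc(C)cc2)NC(=O)NC1c1cccc([N+](=O)[O-])c1`: 24500 nM
- compound 2 `CCOC(=O)C1=C(C[Se]C(=O)c2ccc(C)cc2)N(C)C(=O)NC1c1cccc([N+](=O)[O-])c1`: 32800 nM

Among the measured compounds shown here, in a physicochemical assay, read by spectrophotometry, with a stated time of 10 min (on this read-out higher numbers stand for an effect only at larger amounts of compound and lower numbers for an effect already at smaller amounts), compound 1 gives 24500 nM and stands within the scatter of its only neighbour, compound 2. Compound 3 `CCOC(=O)C1=C(C[Se]C(=O)c2ccc(C)cc2)NC(=O)NC1c1ccc(N(C)C)cc1` carries 4-(dimethylamino)phenyl in place of 3-nitrophenyl on a saturated ring carbon. For the measured compounds named here, the one measured step, a 1.3-fold higher number from compound 1 to compound 2 (0.13 log units; within the scatter), is a different change, methyl in place of hydrogen on an amide-type nitrogen in a ring, so it offers only weak guidance. No step beyond the scatter is therefore expected in this assay, though the uncertainty is wide. The estimated step is a 1.2-fold lower number from compound 1 to compound 3 (0.09 log units; within the scatter). For compound 3 the expected value is 20000 nM, with an estimated range of 6000 nM to 50000 nM.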

Compound 3, half-maximal effective concentration: 29600 nM
Beside the measured number, compound 3's estimate is 1.5-fold (0.17 log units) below it; the range from low to high includes it.
By their numbers in this assay, from the lowest: compounds 1, 3 and 2 (each within the scatter of the next).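

In this assay the exchange of 3-nitrophenyl for 4-(dimethylamino)phenyl on a saturated ring carbon gives a 1.2-fold higher number from compound 1 to compound 3 (0.08 log units; within the scatter) and so leaves the number within the scatter. Among the compounds shown here, this is the first look at this position, and here two quite different aryl groups cannot be told apart. No measurement shown explains this result. As far as these compounds go, whether unsubstituted phenyl, or a phenyl ring carrying a carboxylic acid, would also fit this pattern stays open. So does whether a simple alkyl chain could replace the aryl ring at this position.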